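Swapping Methoxy for Fluoro in a Cytotoxicity Series

This account rests on a few compounds, and the source may have more. Where it says the series, first, only, none or still open, it means among the compounds named here.

Compound 1 `C=CCSc1nnc(-c2cc(OC)c(OC)c(OC)c2)n1N1C(=O)c2ccccc2C1=O` in a functional assay on PC-3M cells (Homo sapiens) for cytotoxicity, read by MTT assay, with a stated time of 48 h (a higher number here means a weaker inhibitor, a lower number a stronger inhibitor), reaches only a limit, > 200000 nM. Within the data shown here, compound 2 `COc1ccc(C(=O)CSc2nnc(-c3cc(OC)c(OC)c(OC)c3)n2N2C(=O)c3ccccc3C2=O)cc1` in this assay gives 32800 nM, the single true number among the values shown. Compound 1 sits at a limit (the limit of > 200000 nM in this assay, at which 1 of the 2 values shown sits). Among the measured compounds shown here, the one measured step, an at least 6.0-fold lower number from compound 1 to compound 2 (0.78 log units; beyond the scatter), changes the group on the sulfur-bound chain carbon. Compound 3 `COc1cc(-c2nnc(SCC(=O)c3ccc(F)cc3)n2N2C(=O)c3ccccc3C2=O)cc(OC)c1OC` differs from compound 2 by fluoro in place of methoxy on an aromatic carbon. For the measured compounds named here, no measured step touches this position, so no change beyond the scatter is expected. Compound 3 is expected at about 30000 nM, with a range from 10000 nM to 100000 nM. This estimate means an expected 1.1-fold lower number from compound 2 to compound 3 (0.04 log units; within the scatter).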

Compound 3, half-maximal inhibitory concentration: > 200000 nM
Compound 3: only a limit was reported; the forecaster's own chance of this, stated with the estimate: 10%; middle value at least 6.6-fold (0.82 log units) away from the limit.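

In this assay, among these compounds, fluoro in place of methoxy gives an at least 6.0-fold higher number from compound 2 to compound 3 (0.78 log units; beyond the scatter), so this position, which no earlier step touched, does matter for the read-out. Compound 3 reaches only a limit: the limit of > 200000 nM in this assay, at which 2 of the 3 values shown sit. The step from compound 1 to compound 3 cannot be read, as both values are limits.

The compounds shown leave open whether methoxy is special here or whether other groups at this place, such as an amine, a hydroxy or an ethoxy, would also keep a measurable number.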